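This account rests on a few compounds, and the source may have more. Where it says the series, first, only, none or still open, it means among the compounds named here.

Measured compounds, all in the same assay:

Compound 1, `CNC(=O)c1ccc(CN(C)C(=O)c2cc(Cl)c(O)cc2O)cc1`: 34800 nM
Compound 2, `COc1cc(CN(C)C(=O)c2cc(Cl)c(O)cc2O)cc(OC)c1OC`: 73100 nM
Compound 3, `Cc1cccc(CN(C)C(=O)c2cc(Cl)c(O)cc2O)c1`: 49300 nM

All three were tested in a functional assay on NCI-H1975 cells (Homo sapiens) for antiproliferative activity, with a stated time of 72 h; a lower number here means a stronger inhibitor of growth, a higher number a weaker inhibitor of growth. In this assay compound 1 gives 34800 nM, the lowest of the three numbers. Compound 3 gives 49300 nM, and the gap between compound 1 and compound 3 lies within the usual scatter of this kind of measurement, so nothing can be made of their order. Compound 2 gives 73100 nM, and here the gap to compound 1 lies beyond the scatter.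

Compound 4, `CCCNC(=O)c1ccc(CN(C)C(=O)c2cc(Cl)c(O)cc2O)cc1`, has not yet been measured. It differs from compound 1 in one place only: ethyl in place of hydrogen on a saturated chain carbon bound to an amide-type nitrogen. Among the measured compounds shown here, no measured pair in this set shows what such a change does, so the expectation rests on compound 1 alone. With nothing in the data pointing either way, the step is expected to be small, a 1.2-fold lower number from compound 1 to compound 4 (0.06 log units; within the scatter), most likely within the scatter in either direction. Compound 4 is therefore expected to give about 30000 nM, with a range from 12000 nM to 80000 nM.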

Compound 4, concentration for 50% growth inhibition: 20800 nM
The estimate for compound 4 lay 1.4-fold (0.16 log units) above the measured number; the range from low to high includes it.
By their numbers in this assay, from the lowest: compounds 4, 1, 3 and 2 (each within the scatter of the next, the first and the last beyond it).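

In this assay, replacing methylcarbamoyl with propylcarbamoyl gives a 1.7-fold lower number from compound 1 to compound 4 (0.22 log units; within the scatter), so this pair cannot be told apart. Among the compounds shown here, this is the first look at this position in the set, and it shows that adding ethyl on the saturated chain carbon bound to the amide-type nitrogen costs no growth inhibition beyond the scatter. Nothing measured here offers an explanation for this result.

As far as these compounds go, whether a longer chain such as hexyl, a ring such as cyclopropyl or phenyl, or a chain ending in an amine or a carboxylic acid would move the number beyond the scatter remains open. A single pair also cannot show whether removing the methyl from this position, leaving only the amide hydrogen, would change the number.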